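Removing the aromatic methyl from compound 1

The source may report more compounds than this note shows. Statements on the series, on what has been measured and on what is new or still open speak of the compounds shown alone.

Among the measured compounds shown here, in a functional assay on MDA-MB-231 cells (Homo sapiens) for antiproliferative activity, with a stated time of 5 days (a higher number here means a weaker inhibitor, a lower number a stronger inhibitor), compound 1 `Cc1ccc(-n2nc(-c3ccc4ccccc4c3)nc2N2C(=O)COC23C=CC(=O)C=C3)cc1` gives 30 nM, the lowest of the three numbers measured so far. Compound 3 `Cc1ccc(-n2nc(-c3ccc4ccccc4c3)nc2N2C(=O)C(C)OC23C=CC(=O)C=C3)cc1` gives 100 nM, and compound 2 `Cc1ccccc1-n1nc(-c2cccc3ccccc23)nc1N1C(=O)COC12C=CC(=O)C=C2` gives 120 nM; both lie beyond the scatter from compound 1.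

The open question is compound 4 `O=C1C=CC2(C=C1)OCC(=O)N2c1nc(-c2ccc3ccccc3c2)nn1-c1ccccc1`. Its change from compound 1 is hydrogen in place of methyl on an aromatic carbon, para to a large group, so that 4-methylphenyl becomes phenyl.

For the measured compounds named here, only one measured step bears on this, and only indirectly. It is a 3.3-fold higher number from compound 1 to compound 3 (0.52 log units; beyond the scatter), a modest step for methyl in place of hydrogen on a saturated ring carbon. That step involves a methyl at a different place, and its direction cannot simply be carried over. Going by the values given here, no measured step tests the aromatic methyl itself, so the expectation remains loose.

Among the compounds with values here, compound 1 holds the lowest number so far, which leaves a slight lean towards a higher number in this assay. The expected step is a 1.5-fold higher number from compound 1 to compound 4 (0.18 log units; within the scatter), and a step beyond the scatter is not expected. For compound 4 the estimated value is 45 nM, with an expected range of 18 nM to 110 nM.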

Compound 4, half-maximal inhibitory concentration: 70 nM
The estimate for compound 4 lay 1.6-fold (0.19 log units) below the measured number; measured number inside the range.
By their numbers in this assay, from the lowest: compound 1; then compounds 4, 3 and 2 (each within the scatter of the next).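

The aromatic methyl now has a direct reading: in this assay, hydrogen in place of methyl on an aromatic carbon, para to a large group, gives a 2.3-fold higher number from compound 1 to compound 4 (0.37 log units; beyond the scatter) and so moves the number beyond the scatter, by a modest amount. The 4-methylphenyl of compound 1 therefore counts for something in this assay, and phenyl does not match it. Together with a 3.3-fold higher number from compound 1 to compound 3 (0.52 log units; beyond the scatter), this shows that both single-place methyl changes shown raise the number, one by removing a methyl and the other by adding one, so the direction of a methyl change in this series depends on where it sits, and no reason for the new step can be drawn from any measured data.

What remains open is whether methyl is the best group at this aromatic carbon or simply the only one shown there, since an ethyl, a methoxy or a chlorine in the same place could fall on either side of compound 1. As far as these compounds go, it also remains open whether the step from 4-methylphenyl to phenyl keeps its size when the rest of compound 1 changes.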